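The compounds below may be only part of what the source reports. "The series", "measured", "known", "first", "only" and "open" are said of these compounds alone.

Measured compounds:
Compound 1 `C=C1C(=O)O[C@H]2CC3=C[C@H](C/C(C)=C/[C@@H](OC(=O)c4ccc(C(F)(F)F)cc4)[C@H]12)OC3=O`: in a functional assay on NCI-H460 cells (Homo sapiens) for cytotoxicity, read by MTT assay, with a stated time of 48 h (on this read-out higher numbers stand for weaker inhibition and lower numbers for stronger inhibition), compound 1 gives > 10000 nM, which is a limit of the assay.
Compound 2 `C=C1C(=O)O[C@H]2CC3=C[C@H](C/C(C)=C/[C@@H](OC(=O)c4ccc([N+](=O)[O-])cc4)[C@H]12)OC3=O`: in this assay compound 2 gives > 10000 nM, again a limit of the assay.
Compound 3 `C=C1C(=O)O[C@H]2CC3=C[C@H](C/C(C)=C/[C@@H](OC(=O)C4CC4)[C@H]12)OC3=O`: in this assay compound 3 gives 3000 nM.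

Compound 2 therefore stands at the limit rather than at a number, and it shares that position with one other compound, as the limit of > 10000 nM in this assay, at which 2 of the 3 values shown sit, shows. The unmeasured compound 4 `C=C1C(=O)O[C@H]2CC3=C[C@H](C/C(C)=C/[C@@H](OC(=O)/C=C/c4cccs4)[C@H]12)OC3=O` differs from compound 2 by 2-(thiophen-2-yl)ethenyl in place of 4-nitrophenyl on a carbonyl carbon. Among the compounds with values here, two measured steps bear on the exchange of the ester group on that carbonyl carbon: an at least 3.3-fold lower number from compound 2 to compound 3 (0.52 log units; beyond the scatter) and an at least 3.3-fold lower number from compound 1 to compound 3 (0.52 log units; beyond the scatter). Both show that leaving the aromatic ester behind lowered the number at least modestly, while a step that the two limits leave unreadable from compound 1 to compound 2 gives no readable size. Compound 4 keeps an aromatic ring in the ester but places it further from the carbonyl, so a move away from the limit towards a lower number is expected in this assay, though with a real chance that only the limit is reported. Compound 4 is expected to give 6000 nM, with a range from 2000 nM to 20000 nM. That estimate corresponds to an expected step of an at least 1.6-fold lower number from compound 2 to compound 4 (0.22 log units; that floor lies within the scatter).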

Compound 4, half-maximal inhibitory concentration: 2900 nM
The estimate for compound 4 lay 2.1-fold (0.32 log units) above the measured number; the range from low to high includes it.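

At the ester carbonyl carbon, an aromatic ring in the group does not by itself keep the number at the limit: with 2-(thiophen-2-yl)ethenyl in this assay, the data show an at least 3.4-fold lower number from compound 2 to compound 4 (0.53 log units; beyond the scatter) and an at least 3.4-fold lower number from compound 1 to compound 4 (0.53 log units; beyond the scatter). The step from the cyclopropyl ester, a 1.0-fold lower number from compound 3 to compound 4 (0.01 log units; within the scatter), shows that in this assay this ring-bearing group cannot be told apart from the small saturated one. Compound 1 and compound 2 alone remain at a limit of the assay, so those two steps have only a floor and no exact size: the limit of > 10000 nM in this assay, at which 2 of the 4 values shown sit.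

The compounds shown do not separate the contribution of the ethenyl link from that of the thiophene ring. They also leave open how an ester carrying an amine, a carboxylic acid or a longer alkyl chain would read in this assay.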